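The source may hold more compounds than are shown below. What is called first, only, known or untested is meant among the compounds shown, and "the series" means these compounds.

Compound 1 `CCCCCCCCCCCCCCCCNC(=O)NC(CCC(=O)O)(CCC(=O)O)CCC(=O)O` gives 350000 nM in an ADME assay on cells (Epithelial cell, Homo sapiens) for cytotoxicity, read by MTT assay; on this read-out higher numbers stand for an effect only at larger amounts of compound and lower numbers for an effect already at smaller amounts. Compound 2 `CCCCCCCCCCCCCCCC(=O)NC(CCC(=O)O)(CCC(=O)O)CCC(=O)O` gives 940000 nM in this assay. Compound 3 `CCCCCCCCCCCCCCCCCCCCNC(=O)NC(CCC(=O)O)(CCC(=O)O)CCC(=O)O` gives 210000 nM in this assay.

Compound 3 carries the lowest of these three numbers. Its gap to compound 1 is the step of a 1.7-fold lower number from compound 1 to compound 3 (0.22 log units; within the scatter), which stays within the scatter; compound 2, with its value of 940000 nM, stands clearly higher than compound 3 in this assay.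

Compound 4 `CCCCCCCCCCCCCCCCCCNC(=O)NC(CCC(=O)O)(CCC(=O)O)CCC(=O)O` has not yet been measured in this assay. It differs from compound 3 by hydrogen in place of ethyl on a saturated chain carbon, ten or more bonds along the chain from an amide-type nitrogen, so compound 4 sits between compound 1 and compound 3 in chain length. Among the compounds with values here, the only step that bears on this change is a 1.7-fold lower number from compound 1 to compound 3 (0.22 log units; within the scatter), where a longer chain gave a small shift within the scatter. No step beyond the scatter is therefore expected for compound 4 in this assay, and the expected step of a 1.3-fold higher number from compound 3 to compound 4 (0.11 log units; within the scatter) is small. Compound 4 is estimated at 270000 nM, with a range from 150000 nM to 500000 nM.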

Compound 4, half-maximal effective concentration: 280000 nM
Compound 4: the middle estimate sits 1.0-fold (0.02 log units) below what was measured, and the stated range covers the measured number.
By their numbers in this assay, from the lowest: compounds 3, 4 and 1 (each within the scatter of the next); then compound 2.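

Compound 4 gives this series a third chain length in this assay, and both of its steps stay within the scatter: a 1.3-fold higher number from compound 3 to compound 4 (0.12 log units; within the scatter) and a 1.3-fold lower number from compound 1 to compound 4 (0.10 log units; within the scatter). The earlier compounds had shown only butyl in place of hydrogen on a saturated chain carbon, ten or more bonds along the chain from an amide-type nitrogen; the smaller ethyl change at this place has now been read in both directions, and it too gives no step beyond the scatter. No measurement at hand accounts for how closely these three chains agree.

The compounds shown leave open whether a longer chain than that of compound 3 would still stay within the scatter. They also leave open whether an amine or a hydroxyl group at this place on the chain would move the number.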